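Stereochemical definition at the chain centre of compound 1

The source may hold more compounds than are shown below. What is called first, only, known or untested is meant among the compounds shown, and "the series" means these compounds.

Compound 1 `CCCC(N)C(=O)NCc1ccccc1` in a functional assay on the whole organism (strain NMRI) with Mus musculus as the target, in the maximal electroshock model, with a stated time of 30 min (a higher number here means that more compound is needed for the effect, a lower number that less compound is needed), gives 39 mg/kg; compound 2 `CN(C)CC(N)C(=O)NCc1ccccc1` in this assay gives 94 mg/kg. Within the data shown here, compound 1 therefore stands with the lowest of the two numbers, and the only measured step is a 2.4-fold higher number from compound 1 to compound 2 (0.38 log units; beyond the scatter). Compound 3 `CCC[C@H](N)C(=O)NCc1ccccc1` differs from compound 1 in no atom or bond: the two compounds have the same atoms and bonds; at least one stereo element is drawn with a configuration in one of them and without one in the other: 1 of 1 stereo elements differ; a stereocentre at a saturated chain carbon is drawn without a configuration in compound 1 and S in compound 3. Among the measured compounds shown here, no measured step concerns a stereocentre, and the step from compound 1 to compound 2 alters a different part of the molecule, so it offers scale but no direction. With the atoms unchanged, a large shift is not anticipated; if the defined configuration is the one carrying most of the effect, a somewhat lower number than compound 1 is expected, and the estimate for compound 3 is 30 mg/kg (range 12 mg/kg to 90 mg/kg), which is expected to correspond to a 1.3-fold lower number from compound 1 to compound 3 (0.11 log units; within the scatter).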

Compound 3, dose for half-maximal effect: > 37 mg/kg
Compound 3: a limit, no number (the forecaster's own chance of this, stated with the estimate: 5%); middle value at least 1.2-fold (0.09 log units) away from the limit.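

In this assay compound 3 gives > 37 mg/kg, a limit and not a number. The step from compound 1 to compound 3 therefore cannot be read. The compounds shown leave open whether the S configuration at the saturated chain carbon alters the dose needed.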